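The source may hold more compounds than are shown below. What is called first, only, known or untested is meant among the compounds shown, and "the series" means these compounds.

Measured so far in a functional assay on the whole organism (strain ICR) for inhibition, with Mus musculus as the target, with a stated time of 4 h, at a dose of 10 mg/kg by the oral route; on this read-out higher numbers stand for more inhibition at the one dose given (going by the name of the read-out) and lower numbers for less inhibition:
compound 1 `CCSCCC12CCC(c3nnc(-c4ccccc4C(F)(F)F)n3C)(CC1)CC2` gives 79%;
compound 2 `Cn1c(-c2ccccc2C(F)(F)F)nnc1C12CCC(CCS(C)(=O)=O)(CC1)CC2` gives 96%;
compound 3 `CCS(=O)(=O)CCC12CCC(c3nnc(-c4ccccc4C)n3C)(CC1)CC2` gives 86%.

Compound 2 stands highest of the three numbers in this assay. Its gap to compound 3 lies within the scatter, so the two cannot be ordered; its gap to compound 1 lies beyond the scatter. Among the compounds with values here, the one measured step that changes the chain end, a number 17 percentage points higher from compound 1 to compound 2 (beyond the scatter), is the only step in the set that bears on the present question.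

Compound 4 `Cn1c(-c2ccccc2C(F)(F)F)nnc1C12CCC(CNS(C)(=O)=O)(CC1)CC2` has not been measured. It differs from compound 2 in one place: methanesulfonamido in place of (methylsulfonyl)methyl on a saturated chain carbon bound to a saturated ring carbon. The sulfur and its two oxygens remain, and the group keeps the same number of heavy atoms, while one hydrogen-bond donor is added.

Within the data shown here, the measured step from compound 1 to compound 2 shows that altering this chain end can move the read-out by a modest amount, but no measured pair shows a sulfonamide in place of a sulfone. With the sulfone of compound 2 already near the top of the read-out, compound 4 is expected to land close to compound 2, with a step of a number 6 percentage points lower from compound 2 to compound 4 (within the scatter) that stays within the scatter. Compound 4 is therefore estimated at 90%, in a range from 75% to 100%.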

Compound 4, a percentage reported as inhibition, in the whole organism at one dose (the size of the read-out at that dose, not a potency): 73%
Beside the measured number, compound 4's estimate is 17 percentage points above it; the whole stated range lies above it.
By their numbers in this assay, from the lowest: compounds 4, 1, 3 and 2 (each within the scatter of the next, the first and the last beyond it).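

The swap of (methylsulfonyl)methyl for methanesulfonamido, on a saturated chain carbon bound to a saturated ring carbon, is the first change shown to keep the sulfur and its two oxygens and the same number of heavy atoms, yet in this assay it gives a number 23 percentage points lower from compound 2 to compound 4 (beyond the scatter). Set against the (ethylsulfanyl)methyl group, the same methanesulfonamido group gives a number 6 percentage points lower from compound 1 to compound 4 (within the scatter), so compound 1 and compound 4 cannot be ordered, and the gain in a number 17 percentage points higher from compound 1 to compound 2 (beyond the scatter) is not carried over to the sulfonamide. No measurement at hand accounts for this difference between the two sulfur-bearing groups.

The compounds shown leave open whether the lower number goes with the hydrogen-bond donor that enters, a question that a methanesulfonamido group carrying a methyl on its nitrogen would address. They also leave open how a longer chain carrying the methanesulfonamido group, or a carboxylic acid on the same saturated chain carbon, would read out at this dose.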